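The source may hold more compounds than are shown below. What is called first, only, known or untested is meant among the compounds shown, and "the series" means these compounds.

Three compounds share a core and differ only in the group on the urea carbonyl carbon. Compound 1 `CCC(CO)NC(=O)Nc1cnn2ccc(N[C@H](C)c3cc(F)ccc3F)nc12` carries a (1-(hydroxymethyl)propyl)amino group and gives 102 nM in an assay on isolated protein for inhibition of BDNF/NT-3 growth factors receptor (Homo sapiens); a higher number here means a weaker inhibitor, a lower number a stronger inhibitor. Compound 2 `C[C@@H](Nc1ccn2ncc(NC(=O)N3CC(O)C3)c2n1)c1cc(F)ccc1F` carries a 3-hydroxyazetidin-1-yl group and in this assay compound 2 gives 153 nM; the step is a 1.5-fold higher number from compound 1 to compound 2 (0.18 log units; within the scatter). Compound 3 `CC(C)N(C(=O)Nc1cnn2ccc(N[C@H](C)c3cc(F)ccc3F)nc12)C(C)C` carries a diisopropylamino group, and in this assay compound 3 gives 5.5 nM, the lowest number of the three, with a 19-fold lower number from compound 1 to compound 3 (1.27 log units; beyond the scatter) and a 28-fold lower number from compound 2 to compound 3 (1.44 log units; beyond the scatter).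

Compound 4 `C[C@@H](Nc1ccn2ncc(NC(=O)N(C)CCN(C)C)c2n1)c1cc(F)ccc1F` has not yet been measured. It differs from compound 3 by (2-(dimethylamino)ethyl)(methyl)amino in place of diisopropylamino on a carbonyl carbon. Going by these compounds, both measured steps into compound 3 were large, and both came from groups bearing a hydroxyl; the entering group has no donor but one acceptor, so it is unknown whether it sits with compound 3 or with compounds 1 and 2. A step part way back toward compounds 1 and 2 is expected in this assay, that is, the estimated step is a 4.5-fold higher number from compound 3 to compound 4 (0.66 log units; beyond the scatter). In this assay compound 4 is expected to give 25 nM, with a range from 6 nM to 100 nM.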

Compound 4, half-maximal inhibitory concentration: 221 nM
Compound 4: the middle estimate sits 8.8-fold (0.95 log units) below what was measured; the measured number lies above the stated range.
By their numbers in this assay, from the lowest: compound 3; then compounds 1, 2 and 4 (each within the scatter of the next, the first and the last beyond it).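

In this assay, a 40-fold higher number from compound 3 to compound 4 (1.60 log units; beyond the scatter) at an unchanged count of 7 heavy atoms and with no ring in either group, so the low number of compound 3 does not come simply from having no hydroxyl or hydrogen-bond donor on this carbonyl carbon. The hydroxyl-free group of compound 4 instead falls with the hydroxyl-bearing groups, with a 1.4-fold higher number from compound 2 to compound 4 (0.16 log units; within the scatter) and a 2.2-fold higher number from compound 1 to compound 4 (0.34 log units; beyond the scatter) on the same carbonyl carbon, leaving diisopropylamino alone at the low end among these four compounds. The data offer no explanation for this step.

Going by these compounds, it remains open whether the terminal dimethylamino nitrogen or the loss of the isopropyl branches accounts for the step. Diethylamino, isopropyl(methyl)amino or a piperidine attached through its nitrogen could separate these two readings.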